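A Longer Tether Where Nothing Inhibited Before

A few compounds are considered here, and "the series" means these few. Any claim that something is new, unique, unknown or untested is made for them only; others in the source may bear on it.

Of the compounds shown here, three have been tested in an assay on isolated protein for inhibition of hexokinase-3 (Rattus norvegicus), with a stated time of 6 h, tested at 10 mM; a lower number here means less inhibition, a higher number more inhibition at the concentration tested (going by the name of the read-out). Compound 3 `O=C(CI)NCCCC(=O)NCCCCCCNc1ncnc2c1ncn2[C@@H]1O[C@H](COP(=O)(O)OP(=O)(O)OP(=O)(O)O)[C@@H](O)[C@H]1O` gives 0%. Compound 1 `O=C(CI)NCCCCCC(=O)NCCCCCCNc1ncnc2c1ncn2[C@@H]1O[C@H](COP(=O)(O)OP(=O)(O)OP(=O)(O)O)[C@@H](O)[C@H]1O` gives 0% in this assay. The change from compound 3 to compound 1 is 2-(((iodomethyl)carbonyl)amino)ethyl in place of ((iodomethyl)carbonyl)amino on a saturated chain carbon, three bonds along the chain from a carbonyl carbon, and the step that came with it was no change at the digits printed from compound 3 to compound 1 (within the scatter). Compound 2 `Nc1ncnc2c1nc(NCCCCNC(=O)CI)n2[C@@H]1O[C@H](COP(=O)(O)OP(=O)(O)OP(=O)(O)O)[C@@H](O)[C@H]1O` gives 0% in this assay, level with the other two at the digits reported. The difference between the core of compound 2 and the core of compound 3 is not broken down here.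

Compound 4 `Nc1ncnc2c1nc(NCCCCCCNC(=O)CI)n2[C@@H]1O[C@H](COP(=O)(O)OP(=O)(O)OP(=O)(O)O)[C@@H](O)[C@H]1O` has not yet been measured. It differs from compound 2 by 2-(((iodomethyl)carbonyl)amino)ethyl in place of ((iodomethyl)carbonyl)amino on a saturated chain carbon, four bonds along the chain from a nitrogen on an aromatic ring. This is the same kind of change as from compound 3 to compound 1, but the place differs: there it sat three bonds along the chain from a carbonyl carbon, here it sits four bonds along the chain from a nitrogen on an aromatic ring. Compound 4 is expected to give 0% in this assay. The step expected is no change at the digits printed from compound 2 to compound 4 (within the scatter), resting on the fact that the earlier change gave no change at the digits printed from compound 3 to compound 1 (within the scatter) and all measured compounds sit at the floor of the read-out. The estimate spans from 0% to 10%.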

Compound 4, a percentage reported as inhibition, at one concentration (the size of the read-out at that concentration, not a potency): 0%
Beside the measured number, compound 4's estimate shows no gap at the digits printed; the measured number falls inside the stated range.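

Placing 2-(((iodomethyl)carbonyl)amino)ethyl in place of ((iodomethyl)carbonyl)amino on the core of compound 2 gives, in this assay, no change at the digits printed from compound 2 to compound 4 (within the scatter). Set beside the earlier case, the change behaves alike on both cores: the same change on two cores in this assay, no change at the digits printed (within the scatter) from compound 3 to compound 1 and no change at the digits printed (within the scatter) from compound 2 to compound 4, 0 percentage points apart, within the scatter of two such steps

For the compounds shown here, this agreement is weak evidence of transfer, since compound 1, compound 2, compound 3 and compound 4 all sit at the floor of the read-out, so it shows only that the change produced no measurable inhibition on either core, not that it would have the same effect on a compound with measurable inhibition.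

The compounds shown leave open whether any compound of this kind can inhibit the enzyme in this assay at all. A longer chain, a chloroacetyl group in place of the iodine-bearing one, or a diphosphate in place of the triphosphate might each answer that, and a compound lifted off the floor would give the change a real test.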